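The source may report more compounds than this note shows. Statements on the series, on what has been measured and on what is new or still open speak of the compounds shown alone.

Going by the values given here, in a functional assay on SW-620 cells (Homo sapiens) for inhibition, read by MTT assay, with a stated time of 48 h (on this read-out higher numbers stand for weaker inhibition and lower numbers for stronger inhibition), compound 2 `Cc1ccc(COc2ccc(C(=O)NC(=S)Nc3ccc(C)c(-c4nc5ccccc5[nH]4)c3)cc2)cc1` gives 60900 nM, the only plain number in this small set. Compound 1 `Cc1ccc(NC(=S)NC(=O)c2ccc(OCc3cccc(Cl)c3)cc2)cc1-c1nc2ccccc2[nH]1` gives > 100000 nM, which is a limit of the assay and not a number. Among the compounds with values here, the one measured step, an at least 1.6-fold lower number from compound 1 to compound 2 (0.21 log units; that floor lies within the scatter), swaps 3-chlorophenyl for 4-methylphenyl on a saturated chain carbon bound to an oxygen on an aromatic ring; because compound 1 sits at the limit of > 100000 nM in this assay, at which 1 of the 2 values shown sits, that step is only a floor and lies within the scatter. Compound 3 `Cc1ccc(NC(=S)NC(=O)c2ccc(OCc3ccccc3Cl)cc2)cc1-c1nc2ccccc2[nH]1` differs from compound 2 by 2-chlorophenyl in place of 4-methylphenyl on a saturated chain carbon bound to an oxygen on an aromatic ring, so a chlorine-bearing ring returns in place of the methyl-bearing one. Within the data shown here, with a single step within the scatter as the only guide, no change beyond the scatter is expected in this assay, though a lean toward weaker inhibition is plausible since compound 1 with its chlorophenyl reached only a limit. The expected step is a 1.6-fold higher number from compound 2 to compound 3 (0.22 log units; within the scatter). Compound 3 is therefore estimated at 100000 nM, within 35000 nM to 300000 nM.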

Compound 3, half-maximal inhibitory concentration: 57100 nM
Beside the measured number, compound 3's estimate is 1.8-fold (0.24 log units) above it; the measured number falls inside the stated range.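

Compound 3 adds a second plain number at this position, and in this assay the change gives a 1.1-fold lower number from compound 2 to compound 3 (0.03 log units; within the scatter). A chlorine-bearing ring therefore need not end at a limit, and 2-chlorophenyl and 4-methylphenyl cannot be told apart here. Changing 3-chlorophenyl to 2-chlorophenyl gives an at least 1.7-fold lower number from compound 1 to compound 3 (0.24 log units; that floor lies within the scatter), which is only a floor, so it shows no change beyond the scatter, because compound 1 stands at a limit: the limit of > 100000 nM in this assay, at which 1 of the 3 values shown sits.

As far as these compounds go, the size of the true gap from compound 1 to compound 3 stays open. So does whether an amine or a carboxylic acid on this ring, or a longer chain in place of the benzyl group, would move the number beyond the scatter.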